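Adding a Methyl to a Short Alkyl Chain on Two Cores

The compounds below may be only part of what the source reports. "The series", "measured", "known", "first", "only" and "open" are said of these compounds alone.

Compound 1, `CCCCCCCCCCn1cc(-c2nc3ccccc3cc2CCCC)nn1`, in a functional assay on HeLa cells (Homo sapiens) for cytotoxicity, read by MTT assay, with a stated time of 24 h (on this read-out lower numbers stand for stronger inhibition and higher numbers for weaker inhibition), gives > 100 ug/mL.
Compound 2, `CCCCCCCCCCn1cc(-c2nc3ccccc3cc2CCCCC)nn1`, in this assay gives > 100 ug/mL.
Compound 3, `CCCc1cc2ccccc2nc1-c1cn(CCC(F)(F)C(F)(F)C(F)(F)C(F)(F)C(F)(F)C(F)(F)C(F)(F)C(F)(F)F)nn1`, in this assay gives 37.8 ug/mL.

The value of compound 1 is a limit of the assay, not a number. The value of compound 2 is also such a limit. Only compound 3 yields a number, and the difference between its core and the core of compound 1 is not broken down here.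

From compound 1 to compound 2 the change is methyl in place of hydrogen on a saturated chain carbon, four bonds along the chain from an aromatic carbon, and the step that the two limits leave unreadable from compound 1 to compound 2, because both sit at the limit of > 100 ug/mL in this assay, at which 2 of the 3 values shown sit.

Compound 4, `CCCCc1cc2ccccc2nc1-c1cn(CCC(F)(F)C(F)(F)C(F)(F)C(F)(F)C(F)(F)C(F)(F)C(F)(F)C(F)(F)F)nn1`, has not been measured. It differs from compound 3 by methyl in place of hydrogen on a saturated chain carbon, three bonds along the chain from an aromatic carbon. This is the same kind of change, but the place is not identical: three bonds along the chain from an aromatic carbon here, four bonds there.

Since the measured step of this kind is unreadable, the expectation rests only on compound 3 and its value 37.8 ug/mL. Compound 4 is expected to sit near it, an estimated step of a 1.1-fold lower number from compound 3 to compound 4 (0.03 log units; within the scatter). Compound 4 is therefore estimated at 35 ug/mL, between 15 ug/mL and 90 ug/mL.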

Compound 4, half-maximal inhibitory concentration: 32.8 ug/mL
For compound 4 the middle estimate is 1.1-fold (0.03 log units) above the measured one, and the stated range covers the measured number.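

In this assay, the methyl added to the core of compound 3 gives a 1.2-fold lower number from compound 3 to compound 4 (0.06 log units; within the scatter), so on this core the change from propyl to butyl makes no difference that the assay can resolve. The same kind of change on the core of compound 1 cannot be read, because the values of compound 1 and compound 2 are both limits of the assay and not numbers: the limit of > 100 ug/mL in this assay, at which 2 of the 4 values shown sit.

Within the data shown here, this leaves only one readable step of this kind, so it does not show whether the result carries from one core to the other, and the two changes also sit in different places, three bonds along the chain from an aromatic carbon on one core and four bonds on the other.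

Going by these compounds, it remains open whether an amine, a carboxylic acid or a longer chain in place of the butyl of compound 4 would shift the value beyond the usual scatter. Also open, on these data alone, is whether any such group would give a readable number on the core of compound 1.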